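This account rests on a few compounds, and the source may have more. Where it says the series, first, only, none or still open, it means among the compounds named here.

Working notes on the series.

Compound 1 `Cc1ccc(S(=O)(=O)N2CCC(Br)CC2)cc1` is the unsubstituted parent. In a functional assay on A2780 cells (Homo sapiens) for antiproliferative activity, read by sulforhodamine B assay, with a stated time of 48 h (on this read-out higher numbers stand for weaker inhibition of growth and lower numbers for stronger inhibition of growth), compound 1 reaches only a limit of the assay, > 100000 nM. Compound 2 `Cc1ccc(S(=O)(=O)N2CC[C@@H](Br)C[C@@H]2CC(C)C)cc1` adds the isobutyl group; in this assay compound 2 gives 39000 nM. The change is isobutyl in place of hydrogen on a saturated ring carbon. The step is an at least 2.5-fold lower number from compound 1 to compound 2 (0.40 log units; beyond the scatter), and its true size is open upward because the limit of > 100000 nM in this assay, at which 2 of the 3 values shown sit, is where the parent sits.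

Compound 3 `Cc1ccc(S(=O)(=O)N2CC=C(Br)CC2)cc1` has a different core. In this assay compound 3 also reaches only a limit of the assay, > 100000 nM. The difference between the core of compound 3 and the core of compound 1 is not broken down here.

Compound 4 `Cc1ccc(S(=O)(=O)N2CCC(Br)=CC2CC(C)C)cc1` has not been measured in this assay. Going by the values given here, it differs from compound 3 by isobutyl in place of hydrogen on a saturated ring carbon, the same change, at the same place, as the one made from compound 1 to compound 2. For the pair compound 3 and compound 4 the step is estimated as an at least 2.5-fold lower number from compound 3 to compound 4 (0.39 log units; beyond the scatter), resting on the earlier step of an at least 2.5-fold lower number from compound 1 to compound 2 (0.40 log units; beyond the scatter) and on the fact that both starting points, compound 1 and compound 3, sit at the limit of > 100000 nM in this assay, at which 2 of the 3 values shown sit. Since the size of that earlier step is only a bound, the new step could be larger than it reads. On this basis compound 4 is expected to give about 40000 nM in this assay. The expected range for compound 4 runs from 12000 nM to 100000 nM, and a further limit-only result cannot be excluded.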

Compound 4, concentration for 50% growth inhibition: 36000 nM
Beside the measured number, compound 4's estimate is 1.1-fold (0.05 log units) above it, and the stated range covers the measured number.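

In this assay, isobutyl in place of hydrogen on a saturated ring carbon gives an at least 2.7-fold lower number from compound 3 to compound 4 (0.44 log units; beyond the scatter), so the lower number seen on the core of compound 1 also appears on a second core. Set side by side, the two results show the same direction on both cores, but they do not establish that the change has the same size on each: the same change on two cores in this assay, an at least 2.5-fold lower number (0.40 log units; beyond the scatter) from compound 1 to compound 2 and an at least 2.7-fold lower number (0.44 log units; beyond the scatter) from compound 3 to compound 4; the limit leaves it open whether they differ

The true size of the change on either core remains unknown, because compound 1 and compound 3 each sit at a limit of the assay rather than at a number: the limit of > 100000 nM in this assay, at which 2 of the 4 values shown sit.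

The compounds shown leave open whether another group on the saturated ring carbon next to the ring nitrogen, such as methyl, a longer chain, benzyl or a chain ending in an amine, would give a different number from isobutyl. Also open, from the compounds shown here alone, is whether the change would carry over with chloro or hydroxyl in place of the bromo group, and whether a parent with a measurable number would allow the size of the step to be read.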